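A Second Methyl on the Amine Nitrogen

This account rests on a few compounds, and the source may have more. Where it says the series, first, only, none or still open, it means among the compounds named here.

Compound 1 `C=C(c1ccc(OC)cc1NC(=O)CN)c1ccc(OC)c2c1C=CC(C)(C)O2`: 200 nM
Compound 2 `C=C(c1ccc(OC)cc1NC(=O)CNC)c1ccc(OC)c2c1C=CC(C)(C)O2`: 500 nM

Among the compounds with values here, in a functional assay on HeLa cells (Homo sapiens) for antiproliferative activity, read by MTT assay, with a stated time of 48 h (a higher number here means a weaker inhibitor, a lower number a stronger inhibitor), compound 2 gives 500 nM, the higher of the two numbers measured so far, which makes it the weaker inhibitor of the pair. Compound 3 `C=C(c1ccc(OC)cc1NC(=O)CN(C)C)c1ccc(OC)c2c1C=CC(C)(C)O2` differs from it in one place: methyl in place of hydrogen on an amine nitrogen. This is methyl in place of hydrogen on an amine nitrogen, turning methylamino into dimethylamino. Within the data shown here, one measured step bears on this change, the same replacement made on the primary amine: a 2.5-fold higher number from compound 1 to compound 2 (0.40 log units; beyond the scatter). Among the measured compounds shown here, that single modest step is the only guide, and the data do not show whether a second methyl repeats the effect of the first. A further modest step towards a higher number in this assay is therefore expected. The estimated step is a 1.8-fold higher number from compound 2 to compound 3 (0.26 log units; within the scatter). The expected value for compound 3 is 900 nM, with a range of 350 nM to 2500 nM.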

Compound 3, half-maximal inhibitory concentration: 790 nM
Estimate against measurement, compound 3: 1.1-fold (0.06 log units) above; the measured number falls inside the stated range.
By their numbers in this assay, from the lowest: compound 1; then compounds 2 and 3 (each within the scatter of the next).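

In this assay, the second methyl on the amine nitrogen gives a 1.6-fold higher number from compound 2 to compound 3 (0.20 log units; within the scatter), so on its own this step cannot be told apart from the scatter, unlike the first methyl, which gave a 2.5-fold higher number from compound 1 to compound 2 (0.40 log units; beyond the scatter). Taken together, the full change of amino to dimethylamino on this saturated chain carbon bound to a carbonyl carbon gives a 4.0-fold higher number from compound 1 to compound 3 (0.60 log units; beyond the scatter), so the two methyls jointly carry a step that the second alone does not clearly show. No measurement shown here explains these steps.

The compounds shown leave open how a longer chain on the amine nitrogen, such as ethyl or propyl, or a ring amine such as pyrrolidine or morpholine, would read in this assay. They also leave open what a hydroxyl or a carboxylic acid in place of the amine would do.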